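Working notes: bromo in place of methoxy on compound 3

The source may report more compounds than this note shows. Statements on the series, on what has been measured and on what is new or still open speak of the compounds shown alone.

Measured so far in a functional assay on HCT-116 cells (Homo sapiens) for antiproliferative activity, read by MTT assay, with a stated time of 72 h; on this read-out higher numbers stand for weaker inhibition and lower numbers for stronger inhibition:
compound 1 `CCOC(=O)c1csc2nc(CN3CCN(C)CC3)c(-c3ccc(Br)cc3)n12`: 93600 nM
compound 2 `Cc1ccc(-c2c(CN3CCCCC3)nc3scc(C(=O)O)n23)cc1`: 13800 nM
compound 3 `COc1ccc(-c2c(CN3CCCCC3)nc3scc(C(=O)O)n23)cc1`: 84600 nM

Compound 3, at 84600 nM, lies within the scatter of compound 1, at 93600 nM, and both numbers sit well above that of compound 2. The next compound is compound 4 `O=C(O)c1csc2nc(CN3CCCCC3)c(-c3ccc(Br)cc3)n12`, which keeps the rest of compound 3 and changes one group: bromo in place of methoxy on an aromatic carbon, para to a large group (bromo in place of methoxy on an aromatic carbon).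

Within the data shown here, the one measured step at this place is a 6.1-fold higher number from compound 2 to compound 3 (0.79 log units; beyond the scatter), with methoxy in place of methyl on an aromatic carbon. Among the measured compounds shown here, no measured pair sets bromo against another group with all else equal. Compound 1 also carries bromo, but it differs from compound 4 in other places too, so compound 1 at 93600 nM says little about bromo alone. In this assay, a move toward a lower number is expected on leaving methoxy, perhaps of similar size to the measured step if bromo tracks methyl. Nothing measured shows that it does, so a smaller move, or none beyond the scatter, remains possible. The estimated step is a 2.8-fold lower number from compound 3 to compound 4 (0.45 log units; beyond the scatter). For compound 4 the estimated value is 30000 nM, with an expected range of 9000 nM to 90000 nM.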

Compound 4, half-maximal inhibitory concentration: > 100000 nM
Compound 4 ended at the assay's limit; the forecaster's own chance of this, stated with the estimate: 10%; middle value at least 3.3-fold (0.52 log units) from the limit.
By their numbers in this assay, from the lowest: compound 2; then compounds 3 and 1 (each within the scatter of the next). At a limit, above all of these: compound 4.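

In this assay compound 4 gives > 100000 nM, which is a limit of the assay and not a number, and it is the only such reading among the compounds shown: the limit of > 100000 nM in this assay, at which 1 of the 4 values shown sits.

Against methoxy, the reading is an at least 1.1-fold higher number from compound 3 to compound 4 (0.07 log units; that floor lies within the scatter), so bromo at this aromatic carbon brings no move to a lower number, although the floor of this step alone does not separate the two groups beyond the scatter. Against methyl, the reading is an at least 7.2-fold higher number from compound 2 to compound 4 (0.86 log units; beyond the scatter), so among the three acids that differ only at this place, methyl is now set apart from both methoxy and bromo, and leaving methoxy does not by itself lower the number.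

As far as these compounds go, how far compound 4 lies past the limit stays unknown, so bromo and methoxy cannot be ordered, and two groups that both read high give no rule for what separates them from methyl. From the compounds shown here alone, whether the lower number of compound 2 extends to an ethyl or a chloro at this place, or survives an amide in place of the carboxylic acid, stays open.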